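A few compounds are considered here, and "the series" means these few. Any claim that something is new, unique, unknown or untested is made for them only; others in the source may bear on it.

The shared core is that of compound 1 `COc1cc(OC)c(-c2coc3cc(OCc4ccc(F)cc4)ccc3c2=O)cc1OC`, which in a functional assay on A-375 cells (Homo sapiens) for antiproliferative activity, read by MTT assay, with a stated time of 24 h (on this read-out lower numbers stand for stronger inhibition and higher numbers for weaker inhibition), gives 1720 nM. Compound 3 `COc1cc(OC)c(-c2coc3cc(OCc4cccc(Cl)c4)ccc3c2=O)cc1OC` gives 980 nM in this assay. Compound 2 `COc1cc(OC)c(-c2coc3cc(OCc4ccc([N+](=O)[O-])cc4)ccc3c2=O)cc1OC` reaches only the limit of this assay, > 10000 nM, a limit and not a number, as noted by the limit of > 10000 nM in this assay, at which 1 of the 3 values shown sits. Compound 2 thus stands at the weak end of the three: an at least 5.8-fold higher number from compound 1 to compound 2 (0.76 log units; beyond the scatter), and an at least 10-fold lower number from compound 2 to compound 3 (1.00 log units; beyond the scatter), both beyond the scatter, while a 1.8-fold lower number from compound 1 to compound 3 (0.24 log units; within the scatter), within it.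

Compound 4 `COc1cc(OC)c(-c2coc3cc(OCc4cccc(C(F)(F)F)c4)ccc3c2=O)cc1OC` is not yet measured. Its change from compound 2 is 3-(trifluoromethyl)phenyl in place of 4-nitrophenyl on a saturated chain carbon bound to an oxygen on an aromatic ring. The closest measured step is an at least 10-fold lower number from compound 2 to compound 3 (1.00 log units; beyond the scatter); read in reverse, an at least 5.8-fold higher number from compound 1 to compound 2 (0.76 log units; beyond the scatter) points the same way, so leaving the 4-nitrophenyl has twice gone with a markedly lower number. A downward step of at least that order is expected, an at least 8.3-fold lower number from compound 2 to compound 4 (0.92 log units; beyond the scatter), though the size is open-ended on the side of compound 2. Compound 4 is therefore estimated at 1200 nM, in the range 500 nM to 4000 nM.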

Compound 4, half-maximal inhibitory concentration: 1140 nM
Beside the measured number, compound 4's estimate is 1.1-fold (0.02 log units) above it; low and high end bracket the measured number.
By their numbers in this assay, from the lowest: compounds 3, 4 and 1 (each within the scatter of the next). At a limit, above all of these: compound 2.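

In this assay, a second group in place of the 4-nitrophenyl gives a clear step, an at least 8.7-fold lower number from compound 2 to compound 4 (0.94 log units; beyond the scatter), and this group holds no nitrogen or oxygen. Compound 2 carries a limit and not a number: the limit of > 10000 nM in this assay, at which 1 of the 4 values shown sits. Trifluoromethyl in place of chloro on an aromatic carbon, a 1.2-fold higher number from compound 3 to compound 4 (0.07 log units; within the scatter), stays within the scatter, as does the change from 4-fluorophenyl, a 1.5-fold lower number from compound 1 to compound 4 (0.18 log units; within the scatter), so this position has now taken three halogen-bearing phenyl groups with no readable difference among compounds 1, 3 and 4.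

Compounds 3 and 4 differ from compound 2 both in the group carried and in where it sits on the phenyl, so these two changes remain unseparated. Going by these compounds, how an amine or a carboxylic acid on that phenyl, or a longer chain in place of the saturated chain carbon, would read also remains open.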